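The source may report more compounds than this note shows. Statements on the series, on what has been measured and on what is new or still open speak of the compounds shown alone.

Working notes on the series, read in a functional assay on HepG2 cells (Homo sapiens) for cytotoxicity, with a stated time of 72 h; a higher number here means that more compound is needed for the effect, a lower number that less compound is needed. Compound 1 (`COc1ccc(/C=C/[C@@](C)(/C=C/c2ccc(O)c(/C=C/C#N)c2)CCC=C(C)C)cc1`) gives > 26000 nM, which is a limit and not a number. Compound 2 (`COc1ccc(/C=C/[C@@](C)(/C=C/c2ccc(O)c(/C=C/C(C)=O)c2)CCC=C(C)C)cc1`) gives > 52000 nM, which is also a limit, so its standing has no numeric value behind it. For the measured compounds named here, the only measured step is a step that the two limits leave unreadable from compound 1 to compound 2, with acetyl in place of cyano on a double-bonded chain carbon bound to a double-bonded chain carbon, and it supplies no size to carry forward.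

Compound 3 (`COc1ccc(/C=C/[C@@](C)(/C=C/c2ccc(O)cc2)CCC=C(C)C)cc1`) follows from compound 2 by hydrogen in place of 2-acetylethenyl on an aromatic carbon, ortho to a hydroxy group. With no readable step to draw on, no change beyond the scatter is expected in this assay, and another limit is likely. The expected step is a step that the limit leaves unreadable from compound 2 to compound 3. For compound 3 the estimate is 60000 nM, with an expected range of 25000 nM to 150000 nM.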

Compound 3, half-maximal effective concentration: > 52000 nM
Compound 3 gave a limit, no number (the forecaster's own chance of this, stated with the estimate: 70%); the middle value does not contradict the limit.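

In this assay compound 1, compound 2 and compound 3 all stand as limits and not numbers, so the steps among them cannot be read. As far as these compounds go, what stays open is whether 2-cyanoethenyl, 2-acetylethenyl or hydrogen at that place makes any difference to the read-out.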